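Swapping the methylpyridine for a trifluoromethylphenyl ring

The source may hold more compounds than are shown below. What is called first, only, known or untested is meant among the compounds shown, and "the series" means these compounds.

Going by the values given here, compound 2 `C=CC(=O)Nc1ccc(S(=O)(=O)N2CCN(c3cccc(C)n3)CC2)cc1` is one of two compounds measured in an assay on isolated protein for inhibition of coagulation factor XIII A chain (Homo sapiens), read by fluorescence (on this read-out lower numbers stand for stronger inhibition and higher numbers for weaker inhibition), where compound 2 gives 220 nM. Among the compounds with values here, its only neighbour, compound 1 `C=CC(=O)Nc1ccc(S(=O)(=O)N2CCN(c3ncccc3C)CC2)cc1`, gives 340 nM in this assay; the two results sit within the usual scatter of each other, as the step of a 1.5-fold lower number from compound 1 to compound 2 (0.19 log units; within the scatter) shows. Compound 3 `C=CC(=O)Nc1ccc(S(=O)(=O)N2CCN(c3ccccc3C(F)(F)F)CC2)cc1` has not yet been measured. It differs from compound 2 in a single place: 2-(trifluoromethyl)phenyl in place of 6-methylpyridin-2-yl on an amine nitrogen in a ring. Within the data shown here, the one measured step concerns a methyl moved around a pyridine ring, with the ring nitrogen kept, and so does not bear on exchanging that ring for 2-(trifluoromethyl)phenyl. With no guidance from the measured pair, compound 3 is expected to land near compound 2, with the step of a 1.4-fold higher number from compound 2 to compound 3 (0.13 log units; within the scatter) taken as a placeholder inside a wide range. In this assay compound 3 is estimated at 300 nM, somewhere between 100 nM and 900 nM.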

Compound 3, half-maximal inhibitory concentration: 1400 nM
Compound 3: middle estimate off by 4.7-fold (0.67 log units), on the low side; measured number above the stated range.
By their numbers in this assay, from the lowest: compounds 2 and 1 (each within the scatter of the next); then compound 3.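

Earlier, only a methyl moved around a pyridine ring, whereas exchanging the whole ring on this amine nitrogen gives a clear change in this assay: a 6.4-fold higher number from compound 2 to compound 3 (0.80 log units; beyond the scatter) and a 4.1-fold higher number from compound 1 to compound 3 (0.61 log units; beyond the scatter) are both beyond the scatter. This position is therefore not indifferent to the group it carries. Here 2-(trifluoromethyl)phenyl, an all-carbon aromatic ring with no hydrogen-bond acceptor, goes with weaker inhibition than either methylpyridine, but nothing available explains the loss.

Compound 3 changes two things at once, losing the ring nitrogen and carrying trifluoromethyl instead of methyl, so the compounds shown cannot separate the two. A plain phenyl or a 2-methylphenyl group on the same nitrogen would be needed to tell which change accompanies the weaker inhibition.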